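Swapping a Hydrogen for Chloro on a Phenyl Ring

A few compounds are considered here, and "the series" means these few. Any claim that something is new, unique, unknown or untested is made for them only; others in the source may bear on it.

Of the compounds shown here, three have been measured in a functional assay on cells (Cancer cell lines, Homo sapiens) for cytotoxicity, read by sulforhodamine B assay, with a stated time of 48 h; on this read-out lower numbers stand for stronger inhibition of growth and higher numbers for weaker inhibition of growth. Compound 1, `COc1ccc(OC)c(-c2cc(-c3ccc(Cl)cc3)nn2-c2ccccc2)c1`, gives 17700 nM. Compound 2, `COc1ccc(OC)c(-c2cc(-c3ccccc3)nn2-c2ccc(S(=O)(=O)NC(C)=O)cc2)c1`, gives 9700 nM. Compound 3, `Oc1ccc(O)c(-c2cc(-c3ccccc3)nn2-c2ccccc2)c1`, gives 17100 nM. Compound 3 stands second highest of the three numbers, yet its nearest neighbour compound 1 and its furthest neighbour compound 2 both lie within the usual scatter, so the three cannot be told apart on this read-out.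

Compound 4, `Oc1ccc(O)c(-c2cc(-c3ccc(Cl)cc3)nn2-c2ccccc2)c1`, has not been measured. It differs from compound 3 by one change: chloro in place of hydrogen on an aromatic carbon. Among the measured compounds shown here, the same swap is already present in compound 1 on a different core, but no matching pair without the chloro exists on that core, so no measured step shows what the change does.

With nothing in the data pointing in either direction, the step from compound 3 to compound 4 is expected to be small, a 1.1-fold lower number from compound 3 to compound 4 (0.06 log units; within the scatter), and not beyond the scatter. Compound 4 is therefore estimated at 15000 nM, with a likely range from 6000 nM to 40000 nM.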

Compound 4, concentration for 50% growth inhibition: 9250 nM
Beside the measured number, compound 4's estimate is 1.6-fold (0.21 log units) above it; the measured number falls inside the stated range.
By their numbers in this assay, from the lowest: compounds 4, 2, 3 and 1 (each within the scatter of the next).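

Among the compounds shown here, this is the first matched pair for the change phenyl to 4-chlorophenyl: in this assay it gives a 1.8-fold lower number from compound 3 to compound 4 (0.27 log units; within the scatter). On this core, then, a chloro can sit on this ring, para to a large group, with no effect that can be told from repeat scatter. Nothing measured here bears on why the step has this size.

The compounds shown leave open whether a different group at the same position, such as a fluoro, an amine or a carboxylic acid, would move the number beyond the scatter. As far as these compounds go, the core of compound 1 has no partner lacking the chloro, so it also remains open whether the same swap would give a similar step on that core.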